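Anilide tail of compound 1: chloro for methoxycarbonyl

The source may hold more compounds than are shown below. What is called first, only, known or untested is meant among the compounds shown, and "the series" means these compounds.

Measured so far:
compound 1 `CCn1c(CNc2ccccc2)nnc1SCC(=O)Nc1ccc(C(=O)OC)cc1` 540 nM
compound 2 `CCC(=O)c1ccc2oc(CS(=O)(=O)c3nnc(CNc4ccccc4)n3CC)nc2c1` 1670 nM
compound 3 `CC/C(=N/OC)c1ccc2oc(CSc3nnc(CNc4ccccc4)n3CC)nc2c1` > 1000 nM

In an assay on isolated protein for inhibition of long-chain fatty acid transport protein 1 (Homo sapiens) (a higher number here means a weaker inhibitor, a lower number a stronger inhibitor), compound 1 gives 540 nM, the lowest of the two numbers. Compound 2 gives 1670 nM, a gap that lies beyond the scatter. For compound 3 only a limit is reported, (the limit of > 1000 nM in this assay, at which 1 of the 3 values shown sits), and no number.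

Compound 4 `CCn1c(CNc2ccccc2)nnc1SCC(=O)Nc1ccc(Cl)cc1` keeps the core of compound 1 and changes only the anilide end: chloro in place of methoxycarbonyl on an aromatic carbon. Among the compounds with values here, no measured step of this kind exists, so the expectation rests on compound 1 alone. The step from compound 1 to compound 4 is expected to be a 1.3-fold higher number from compound 1 to compound 4 (0.11 log units; within the scatter), within the scatter or a slight rise. Compound 4 is estimated at 700 nM, in the range 250 nM to 2000 nM.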

Compound 4, half-maximal inhibitory concentration: > 1000 nM
Compound 4: a limit, no number; the forecaster's own chance of this, stated with the estimate: 20%; at least 1.4-fold (0.15 log units) between middle value and limit.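

Within the data shown here, this is the first change that can be read at a single place: going from 4-(methoxycarbonyl)phenyl to 4-chlorophenyl gives an at least 1.8-fold higher number from compound 1 to compound 4 (0.26 log units; that floor lies within the scatter). As far as these compounds go, compound 4 has only a limit and no number, so the real size of the step stays unknown. Because that floor lies within the scatter, the result does not yet prove that this position is sensitive: the limit of > 1000 nM in this assay, at which 2 of the 4 values shown sit.

From the compounds shown here alone, whether methoxycarbonyl itself matters here, or only some group larger than chloro, stays open. A carboxylic acid, a primary amide or a nitrile on the same carbon would separate these readings.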